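Piperazine ring nitrogen: oxetan-3-yl to methyl

The compounds below may be only part of what the source reports. "The series", "measured", "known", "first", "only" and "open" are said of these compounds alone.

For the measured compounds named here, compound 3 `CN(C[C@H]1Cc2c(cccc2N2CCN(C3COC3)CC2)CN1)[C@H]1CCCc2cccnc21` gives 725 nm/s in an ADME assay for permeability, using PAMPA, at pH 7.4 (on this read-out lower numbers stand for lower permeability and higher numbers for higher permeability), the highest of the three numbers so far; compound 2 `c1cnc2c(c1)CCC[C@@H]2N(CC1CC1)C[C@H]1Cc2c(cccc2N2CCNCC2)CN1` gives 87 nm/s and compound 1 `CCCN(C[C@H]1Cc2c(cccc2N2CCNCC2)CN1)[C@H]1CCCc2cccnc21` gives 26.5 nm/s. Compound 4 `CN1CCN(c2cccc3c2C[C@H](CN(C)[C@H]2CCCc4cccnc42)NC3)CC1` is not yet measured; it differs from compound 3 by methyl in place of oxetan-3-yl on an amine nitrogen in a ring. Going by the values given here, no measured pair isolates a change at this ring nitrogen. Among the compounds with values here, the one measured step, a 3.3-fold higher number from compound 1 to compound 2 (0.52 log units; beyond the scatter), sits on a saturated chain carbon bound to an amine nitrogen, a different place, and compound 2 differs from compound 3 in more than one place, so neither tells how the ring nitrogen substituent alone moves this assay. The expectation therefore rests on little more than the high starting point of compound 3 and a wide allowance for a step in either direction. Compound 4 is expected to give about 400 nm/s in this assay, within 130 nm/s to 1200 nm/s. The step this estimate implies is a 1.8-fold lower number from compound 3 to compound 4 (0.26 log units; within the scatter), and a result well beyond the scatter either way would not be surprising.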

Compound 4, apparent permeability: 996 nm/s
For compound 4 the middle estimate is 2.5-fold (0.40 log units) below the measured one; measured number inside the range.
By their numbers in this assay, from the lowest: compound 1; then compound 2; then compounds 3 and 4 (each within the scatter of the next).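

At the amine nitrogen in a ring, this assay now has its first pair that isolates the substituent: methyl in place of oxetan-3-yl gives a 1.4-fold higher number from compound 3 to compound 4 (0.14 log units; within the scatter). Within this one pair, the exchange of the four-membered ring and its hydrogen-bond acceptor for a single carbon leaves the read-out within the scatter, so the two groups cannot be told apart at this position. No measurement at hand bears on why the two groups read alike.

Compounds with a hydrogen on this nitrogen differ from compound 3 and compound 4 in another place as well, so that change cannot be read alone. As far as these compounds go, whether the same level holds with an acetyl group, or with a longer chain ending in a carboxylic acid, remains open.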